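Methyl for methylsulfonyl on a nitrobenzyl indazole

The source may report more compounds than this note shows. Statements on the series, on what has been measured and on what is new or still open speak of the compounds shown alone.

Compound 1 `O=[N+]([O-])c1cccc(CNc2cc(C(F)(F)F)cc3[nH]ncc23)c1`: > 100000 nM
Compound 2 `O=[N+]([O-])c1ccc(O)cc1CNc1cc(Br)cc2[nH]ncc12`: 910 nM
Compound 3 `CS(=O)(=O)c1ccc(CNc2cc(C(F)(F)F)cc3[nH]ncc23)c([N+](=O)O)c1`: 58000 nM

In an assay for inhibition of Indoleamine 2,3-dioxygenase 1 (Homo sapiens), with stated times of 10 min and 60 min (on this read-out lower numbers stand for stronger inhibition and higher numbers for weaker inhibition), compound 1 gives only a limit, > 100000 nM, as the evidence notes (the limit of > 100000 nM in this assay, at which 1 of the 3 values shown sits). Compound 2 gives 910 nM in this assay. Compound 3 gives 58000 nM, the higher of the two numbers, and its gap to compound 2 lies beyond the scatter.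

Compound 4 `Cc1ccc(CNc2cc(C(F)(F)F)cc3[nH]ncc23)c([N+](=O)O)c1` differs from compound 3 in one place: methyl in place of methylsulfonyl on an aromatic carbon. Among the compounds with values here, no measured pair shows this change, so its effect is open. The estimate for compound 4 is a small step, a 1.5-fold lower number from compound 3 to compound 4 (0.16 log units; within the scatter), within the scatter. Compound 4 is expected to give about 40000 nM, between 10000 nM and 150000 nM.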

Compound 4, half-maximal inhibitory concentration: > 100000 nM
Compound 4 was reported as a limit (the forecaster's own chance of this, stated with the estimate: 25%); middle value at least 2.5-fold (0.39 log units) away from the limit.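

Methyl in place of methylsulfonyl on this aromatic carbon gives an at least 1.7-fold higher number from compound 3 to compound 4 (0.23 log units; that floor lies within the scatter), so this change brings no gain in inhibition at this position. The floor of that step does not by itself show that methylsulfonyl is better than methyl here. Compound 4 stands at a limit in this assay, not at a number: the limit of > 100000 nM in this assay, at which 2 of the 4 values shown sit.

Going by these compounds, how far the step actually reaches stays open. So does what an amine or a carboxylic acid on this same carbon would give.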